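A few compounds are considered here, and "the series" means these few. Any claim that something is new, unique, unknown or untested is made for them only; others in the source may bear on it.

Measured compounds:
Compound 1 `O=c1c2c(C(F)(F)F)cc(-c3ccccc3)nc2ncn1Cc1cn(CCC(F)(F)C(F)(F)C(F)(F)C(F)(F)C(F)(F)C(F)(F)C(F)(F)C(F)(F)F)nn1` — > 200 ug/mL (a limit of the assay)
Compound 2 `CCCCCCCCCCn1cc(Cn2cnc3nc(-c4ccccc4)cc(C(F)(F)F)c3c2=O)nn1` — 8.16 ug/mL

In a functional assay on U-937 cells (Homo sapiens) for cytotoxicity, read by MTT assay, with a stated time of 24 h (a higher number here means a weaker inhibitor, a lower number a stronger inhibitor), compound 1 reaches only a limit, > 200 ug/mL, which is not a number; this is the limit of > 200 ug/mL in this assay, at which 1 of the 2 values shown sits. In this assay compound 2 gives 8.16 ug/mL. Compound 3 `CCc1nc2nc(-c3ccccc3)cc(C(F)(F)F)c2c(=O)n1Cc1cn(CCC(F)(F)C(F)(F)C(F)(F)C(F)(F)C(F)(F)C(F)(F)C(F)(F)C(F)(F)F)nn1` differs from compound 1 by ethyl in place of hydrogen on an aromatic carbon. Within the data shown here, no measured step of this kind is available. The step of a number no higher from compound 1 to compound 3 (the limit leaves the size open) is expected to be none beyond the scatter. Compound 3 is therefore estimated at 200 ug/mL, between 80 ug/mL and 400 ug/mL, most likely again reported only as a limit.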

Compound 3, half-maximal inhibitory concentration: > 200 ug/mL
Compound 3: no number, only a limit; the forecaster's own chance of this, stated with the estimate: 75%; the middle value lies on the limit itself.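

In this assay, among these compounds, compound 1 and compound 3 both reach only a limit, and no step between them can be read: the limit of > 200 ug/mL in this assay, at which 2 of the 3 values shown sit.

In this assay the compounds shown leave open whether ethyl in place of hydrogen on an aromatic carbon changes the value at all.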